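The source may hold more compounds than are shown below. What is called first, only, known or untested is meant among the compounds shown, and "the series" means these compounds.

In a functional assay on B16 cells (Mus musculus) for antiproliferative activity, read by MTT assay, with a stated time of 24 h (a lower number here means a stronger inhibitor, a higher number a weaker inhibitor), compound 1 `C#CCOc1ccc2c(=O)c(-c3cc(OC)c(OC)cc3OC)coc2c1` gives 4500 nM. Compound 2 `COc1cc(OC)c(-c2coc3cc(OCC(=O)c4cccc(C(F)(F)F)c4)ccc3c2=O)cc1OC` is reported at > 10000 nM, which is a limit of the assay and not a number. It therefore has no exact position, and (the limit of > 10000 nM in this assay, at which 1 of the 2 values shown sits). Compound 3 `COc1cc(OC)c(-c2coc3cc(OCc4ccc(F)cc4)ccc3c2=O)cc1OC` differs from compound 2 by 4-fluorophenyl in place of (3-(trifluoromethyl)phenyl)carbonyl on a saturated chain carbon bound to an oxygen on an aromatic ring. One measured step changes the same place, an at least 2.2-fold higher number from compound 1 to compound 2 (0.34 log units; beyond the scatter). It shows that a change here can move the number, but it gives only a minimum size and says nothing direct about the incoming group. A modest move towards a lower number is expected, with compound 1 at 4500 nM as the nearest measured reference. The expected change is an at least 1.4-fold lower number from compound 2 to compound 3 (0.15 log units; that floor lies within the scatter). For compound 3 the estimate is 7000 nM, with an expected range from 2500 nM to 20000 nM.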

Compound 3, half-maximal inhibitory concentration: 1120 nM
Compound 3: the middle estimate sits 6.3-fold (0.80 log units) above what was measured; the measured number lies below the stated range.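

In this assay this place, on a saturated chain carbon bound to an oxygen on an aromatic ring, now shows movement towards a lower number as well as a higher one: 4-fluorophenyl in place of ethynyl gives a 4.0-fold lower number from compound 1 to compound 3 (0.60 log units; beyond the scatter). Replacing (3-(trifluoromethyl)phenyl)carbonyl with 4-fluorophenyl gives an at least 8.9-fold lower number from compound 2 to compound 3 (0.95 log units; beyond the scatter), which is only a minimum size. Compound 2 is held at a limit of the assay and not a number: the limit of > 10000 nM in this assay, at which 1 of the 3 values shown sits.

That replacement removes the carbonyl and changes the ring substituent in a single step, so the compounds shown cannot separate the two changes. On these data alone, how an unsubstituted phenyl or an amine at this place would read remains open.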